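Pyridin-2-ylmethylamine in place of benzyl(methyl)amine on the core

This account rests on a few compounds, and the source may have more. Where it says the series, first, only, none or still open, it means among the compounds named here.

The three measured compounds share one core and differ at the saturated chain carbon bound to an aromatic carbon. Compound 1 `COc1cccc(-c2c(C)n(Cc3ccccc3F)c3nc(C(C)(C)C)c(CN(C)C)n3c2=O)c1` gives 1700 nM in an assay on isolated protein for binding affinity to Gonadotropin-releasing hormone receptor (Homo sapiens); a higher number here means a weaker inhibitor, a lower number a stronger inhibitor. Compound 2 `COc1cccc(-c2c(C)n(Cc3ccccc3F)c3nc(C(C)(C)C)c(CN(C)Cc4ccccc4)n3c2=O)c1` gives 72 nM in this assay, and compound 3 `COC(=O)C(C)(C)c1nc2n(Cc3ccccc3F)c(C)c(-c3cccc(OC)c3)c(=O)n2c1CN(C)Cc1ccccc1` gives 59 nM. Among these three numbers compound 2 stands second highest: its gap to compound 3 is a 1.2-fold lower number from compound 2 to compound 3 (0.09 log units; within the scatter), whereas the step of a 24-fold lower number from compound 1 to compound 2 (1.37 log units; beyond the scatter) sets it far apart from compound 1.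

Compound 4 `COc1cccc(-c2c(C)n(Cc3ccccc3F)c3nc(C(C)(C)C)c(CNCc4ccccn4)n3c2=O)c1` has not yet been measured. It differs from compound 2 in one place: ((pyridin-2-yl)methyl)amino in place of benzyl(methyl)amino on a saturated chain carbon bound to an aromatic carbon. Going by the values given here, the only measured step at this position is a 24-fold lower number from compound 1 to compound 2 (1.37 log units; beyond the scatter), which shows that a change here can be large. Among the compounds with values here, compound 4 keeps a six-membered aromatic ring on the amine, so the bulk of that step is presumably retained, but no measured step covers the loss of the methyl on the amine nitrogen or the hetero atom in the ring. The expected step from compound 2 to compound 4 is therefore small, in either direction, and may well lie within the scatter. This amounts to an expected 1.4-fold higher number from compound 2 to compound 4 (0.14 log units; within the scatter). Compound 4 is accordingly estimated at 100 nM, within 25 nM to 400 nM.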

Compound 4, inhibition constant: 30 nM
Compound 4: the middle estimate sits 3.3-fold (0.52 log units) above what was measured; low and high end bracket the measured number.
By their numbers in this assay, from the lowest: compounds 4, 3 and 2 (each within the scatter of the next, the first and the last beyond it); then compound 1.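

In this assay, putting ((pyridin-2-yl)methyl)amino in place of benzyl(methyl)amino on a saturated chain carbon bound to an aromatic carbon gives a 2.4-fold lower number from compound 2 to compound 4 (0.38 log units; beyond the scatter) and so shows that this position still responds beyond the scatter when a six-membered aromatic ring is already on the amine, which the earlier step alone could not show. Measured from the dimethylamino group, the same entering group gives a 57-fold lower number from compound 1 to compound 4 (1.75 log units; beyond the scatter) and thus goes further than the benzyl(methyl)amino group did, so the large drop at this position survives both the loss of the methyl on the amine nitrogen and the hetero atom in the ring. The change makes these two alterations at once and also adds a hydrogen-bond donor, and nothing available explains the step or assigns it to any one of them.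

Benzylamino and methyl((pyridin-2-yl)methyl)amino would each separate these alterations, but neither is among the compounds shown. Also open, from the compounds shown here alone, are how a pyridin-3-yl or pyridin-4-yl ring, or a longer chain such as 2-(pyridin-2-yl)ethylamino, would compare on this core.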